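The source may hold more compounds than are shown below. What is called first, only, known or untested is meant among the compounds shown, and "the series" means these compounds.

In an in vitro ADME assay on microsomes from liver (Macaca fascicularis) for metabolic stability (on this read-out lower numbers stand for slow clearance and higher numbers for fast clearance), three compounds built on a shared core have been measured. Compound 1 `CC[C@H](C)[C@@H]1C(=O)N[C@H](C2Cc3ccccc3C2)C(=O)N1[C@@H](C(=O)N(C)C)c1ccc(C)nc1C` reads 14 mL.min-1.g-1 and compound 2 `CC[C@H](C)[C@@H]1C(=O)N[C@H](C2Cc3ccccc3C2)C(=O)N1[C@@H](C(=O)N(C)C)c1cnc(C)cc1C` reads 32 mL.min-1.g-1 while compound 3 `CC[C@H](C)[C@@H]1C(=O)N[C@H](C2Cc3ccccc3C2)C(=O)N1[C@@H](C(=O)NC)c1cc(C)cnc1C` reads 5 mL.min-1.g-1 which is the lowest of the three. The next structure is compound 4 `CC[C@H](C)[C@@H]1C(=O)N[C@H](C2Cc3ccccc3C2)C(=O)N1[C@@H](C(=O)N(C)C)c1cc(C)cnc1C` and it differs from compound 3 in one place only: methyl in place of hydrogen on an amide-type nitrogen with methyl in place of hydrogen on an amide-type nitrogen, so methylcarbamoyl becomes dimethylcarbamoyl.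

Going by the values given here, no measured step isolates this change. Among the compounds with values here, the single measured step, a 2.3-fold higher number from compound 1 to compound 2 (0.36 log units; beyond the scatter), concerns a different group, yet it shows that the number can shift modestly while dimethylcarbamoyl stays in place. Compound 1 at 14 mL.min-1.g-1 and compound 2 at 32 mL.min-1.g-1 both carry dimethylcarbamoyl and both lie above compound 3, although they also differ from it in a second place. This points to a moderate rise, so the expected step is a 2.4-fold higher number from compound 3 to compound 4 (0.38 log units; beyond the scatter) in this assay on this limited evidence. For compound 4 the estimated value is 12 mL.min-1.g-1 with an expected range of (6 mL.min-1.g-1 to 25 mL.min-1.g-1).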

Compound 4, intrinsic clearance in microsomes: 13 mL.min-1.g-1
For compound 4 the middle estimate is 1.1-fold (0.03 log units) below the measured one; low and high end bracket the measured number.
By their numbers in this assay, from the lowest: compound 3; then compounds 4 and 1 (each within the scatter of the next); then compound 2.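

In this assay, going by these compounds alone, this pair isolates the methyl on the amide-type nitrogen for the first time, with a 2.6-fold higher number from compound 3 to compound 4 (0.41 log units; beyond the scatter) as the only structural change, so adding this one carbon to methylcarbamoyl to give dimethylcarbamoyl is enough to move the number beyond the scatter. With dimethylcarbamoyl held in place, the ring substituents can now be compared as well: a 2.5-fold lower number from compound 2 to compound 4 (0.39 log units; beyond the scatter) sets 4,6-dimethylpyridin-3-yl apart, while a 1.1-fold lower number from compound 1 to compound 4 (0.03 log units; within the scatter) leaves 2,5-dimethylpyridin-3-yl and 2,6-dimethylpyridin-3-yl indistinguishable in this assay. Nothing available explains the size of any of these steps.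

On these data alone, whether the methyl gives a similar step alongside 2,6-dimethylpyridin-3-yl or 4,6-dimethylpyridin-3-yl remains open. Also open, as far as these compounds go, is how a longer chain on that nitrogen, such as ethyl or propyl, would compare with methyl.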